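This account rests on a few compounds, and the source may have more. Where it says the series, first, only, none or still open, it means among the compounds named here.

In a functional assay on RAW cells (Mus musculus) for inhibition, with a stated time of 24 h (on this read-out higher numbers stand for weaker inhibition and lower numbers for stronger inhibition), compound 1 `COc1ccc(OC)c(C(=O)/C=C/c2ccco2)c1` gives 5700 nM. Compound 2 `COc1ccc(OC)c(C(=O)/C=C/c2ccc(C)o2)c1` has no number on this read-out, only a limit: > 10000 nM. Going by the values given here, the one measured step, an at least 1.7-fold higher number from compound 1 to compound 2 (0.24 log units; that floor lies within the scatter), comes with methyl in place of hydrogen on an aromatic carbon. Compound 3 `COc1ccc(OC)c(C(=O)/C=C/c2ccc(C)s2)c1` shares the core of compound 2 and differs from it in a single group: 5-methylthiophen-2-yl in place of 5-methylfuran-2-yl on a double-bonded chain carbon bound to a double-bonded chain carbon. This places 5-methylthiophen-2-yl in place of 5-methylfuran-2-yl on a double-bonded chain carbon bound to a double-bonded chain carbon. Among the compounds with values here, no measured step makes this exchange, so the methyl step bears on it only loosely, and it gives no direction. No change beyond the scatter is therefore expected in this assay. The expected step is an at least 1.2-fold lower number from compound 2 to compound 3 (0.09 log units; that floor lies within the scatter). For compound 3 the estimated value is 8000 nM, with an expected range of 3000 nM to 20000 nM.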

Compound 3, half-maximal inhibitory concentration: 6700 nM
The estimate for compound 3 lay 1.2-fold (0.08 log units) above the measured number; the measured number falls inside the stated range.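

Replacing 5-methylfuran-2-yl with 5-methylthiophen-2-yl on a double-bonded chain carbon bound to a double-bonded chain carbon gives an at least 1.4-fold lower number from compound 2 to compound 3 (0.17 log units; that floor lies within the scatter) and so provides no firm direction or size for this exchange. Replacing furan-2-yl with 5-methylthiophen-2-yl gives a 1.2-fold higher number from compound 1 to compound 3 (0.07 log units; within the scatter) and shows that a measured number can be retained at this place with a methylated ring. Compound 2 has a limit and not a number, which leaves the true size of its step to compound 3 unknown: the limit of > 10000 nM in this assay, at which 1 of the 3 values shown sits.

Going by these compounds alone, how thiophen-2-yl without the methyl would read in this assay remains open, so the methyl step on furan has no counterpart on the sulfur ring. Also open, from the compounds shown here alone, is how an amine or a carboxylic acid in place of that methyl would read.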